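Working notes: the amine nitrogen substituent and growth inhibition

This account rests on a few compounds, and the source may have more. Where it says the series, first, only, none or still open, it means among the compounds named here.

Among the compounds with values here, compound 2 `Cc1ccc(N2CCN(C(=S)SCc3ccc(C(=O)Nc4ccccc4N)cc3)CC2)cc1` gives 24% in a functional assay on HeLa cells (Homo sapiens) for antiproliferative activity, read by CCK-8 assay, with a stated time of 72 h, tested at 8 uM (on this read-out higher numbers stand for a stronger effect at the one concentration tested and lower numbers for a weaker effect), and stands lowest of the two numbers so far; the nearest measured compound is compound 1 `Nc1ccccc1NC(=O)c1ccc(CSC(=S)N2CCN(c3cccnc3)CC2)cc1`, which gives 72.5% in this assay. Within the data shown here, the one measured step, a number 48.5 percentage points lower from compound 1 to compound 2 (beyond the scatter), came from 4-methylphenyl in place of pyridin-3-yl on an amine nitrogen in a ring. Compound 3 `CN1CCN(C(=S)SCc2ccc(C(=O)Nc3ccccc3N)cc2)CC1` is not yet measured and differs from compound 2 by methyl in place of 4-methylphenyl on an amine nitrogen in a ring. Among the measured compounds shown here, no measured step exchanges a ring group for methyl at this position, so the single known step does not carry over directly; it shows only that the group on this amine nitrogen can move the read-out strongly. A step in either direction is possible, and a modest rise with wide uncertainty is expected. Compound 3 is estimated at 35%, from 10% to 65%, which would mean an expected step of a number 11 percentage points higher from compound 2 to compound 3 (beyond the scatter).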

Compound 3, a percentage reported as inhibition, at one concentration (the size of the read-out at that concentration, not a potency): 75.7%
Estimate against measurement, compound 3: 40.7 percentage points below; measured number above the stated range.
By their numbers in this assay, from the lowest: compound 2; then compounds 1 and 3 (each within the scatter of the next).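

In this assay, methyl in place of 4-methylphenyl gives a number 51.7 percentage points higher from compound 2 to compound 3 (beyond the scatter), so the low read-out of compound 2 does not extend to every group on this amine nitrogen. Methyl in place of pyridin-3-yl gives a number 3.2 percentage points higher from compound 1 to compound 3 (within the scatter), so across these compounds a high read-out occurs both with an aromatic ring on this nitrogen and with no ring at all, and only the 4-methylphenyl group goes with the low number. No measurement available here speaks to what lies behind the difference between these groups.

The compounds shown leave open whether the low read-out follows the phenyl ring or its methyl group, which a plain phenyl on this nitrogen would separate. Also open, as far as these compounds go, is the read-out with an ethyl group, a longer alkyl chain or a benzyl group at this position.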